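The source may hold more compounds than are shown below. What is called first, only, known or untested is meant among the compounds shown, and "the series" means these compounds.

Measured compounds in an assay on isolated protein for inhibition of Ectonucleotide pyrophosphatase/phosphodiesterase family member 1 (Homo sapiens), tested at 10 uM; a lower number here means less inhibition, a higher number more inhibition at the concentration tested (going by the name of the read-out):

compound 1 `CCOC(=O)c1cccc(NC(=O)CSc2nc3cccnc3[nH]2)c1` — 15%
compound 2 `CCn1c(=O)[nH]c(=O)c2nc(SCC(=O)Nc3ccc(OC)c(OC)c3)[nH]c21` — 43%
compound 3 `COc1ccc(NC(=O)CSc2nc3ccc(N(C)C)nc3[nH]2)cc1OC` — 58%

Compound 1 stands lowest of the three numbers. Compound 2 sits nearest to it, with a number higher by an amount beyond the usual scatter, and compound 3 sits furthest, higher by more still. Compound 1 thus has the lowest inhibition of the measured set in this assay, and the whole set remains modest at the concentration tested.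

Compound 4 `O=C(CSc1nc2cccnc2[nH]1)Nc1ccccc1` has not been measured. It differs from compound 1 in one place: hydrogen in place of ethoxycarbonyl on an aromatic carbon. Going by the values given here, no step between two measured compounds exists that would show what removing this group does, so the expectation rests on compound 1 alone. Compound 1 already has a low number in this assay with 15%, which leaves little room for a fall and no basis for a rise. The step from compound 1 to compound 4 is expected to be a number 3 percentage points lower from compound 1 to compound 4 (within the scatter), that is, no change beyond the scatter. Compound 4 is therefore estimated at 12% in this assay, within a range from 0% to 35%.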

Compound 4, a percentage reported as inhibition, at one concentration (the size of the read-out at that concentration, not a potency): 30%
For compound 4 the middle estimate is 18 percentage points below the measured one; low and high end bracket the measured number.
By their numbers in this assay, from the lowest: compound 1; then compound 4; then compound 2; then compound 3.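

In this assay, going by these compounds alone, hydrogen in place of ethoxycarbonyl on an aromatic carbon gives a number 15 percentage points higher from compound 1 to compound 4 (beyond the scatter), the only step so far that isolates a single place. On this core, the ethoxycarbonyl group is therefore not needed for the inhibition seen at the concentration tested, and the compound carrying it has the lower number. Nothing available accounts for the size or direction of this step.

Going by these compounds, whether another group at this place, such as a carboxylic acid, an amine or a methoxy group, would give a number above or below that of compound 4 remains open. On these data alone, compound 2 and compound 3 differ from compound 4 in more than one place, so whether the step holds on their cores also remains open.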